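The source may hold more compounds than are shown below. What is called first, only, known or untested is meant among the compounds shown, and "the series" means these compounds.

Compound 1, with the structure `Cn1c(=O)c(=O)n(C2CCCC2)c2nc(N/N=C/c3ccco3)ncc21`, was tested in a functional assay on HCT-116 cells (Homo sapiens) for antiproliferative activity, read by MTT assay (a higher number here means a weaker inhibitor, a lower number a stronger inhibitor), where compound 1 gives 78700 nM. Among the measured compounds shown here, that is the highest of the two numbers measured so far. For the measured compounds named here, the only other measured compound is compound 2, with the structure `Cn1c(=O)c(=O)n(C2CCCC2)c2nc(N/N=C/c3cc(C(F)(F)F)cc(C(F)(F)F)c3)ncc21`; in this assay compound 2 gives 4360 nM, a lower number by a gap that lies beyond the usual scatter of repeated measurements.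

Compound 3, with the structure `Cn1c(=O)c(=O)n(C2CCCC2)c2nc(N/N=C/c3ccccc3F)ncc21`, has not yet been measured. It differs from compound 1 in one place: 2-fluorophenyl in place of furan-2-yl on a carbon with a double bond to nitrogen. The six-membered aromatic ring of carbon only thus replaces the five-membered aromatic ring with one hetero atom, and the single hydrogen-bond acceptor of the leaving group is gone.

A step downward is expected, estimated as a 3.9-fold lower number from compound 1 to compound 3 (0.59 log units; beyond the scatter), because compound 2, which also carries a six-membered aromatic ring of carbon only, gives 4360 nM. For compound 3 the expected value in this assay is 20000 nM, within a range from 6000 nM to 65000 nM.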

Compound 3, half-maximal inhibitory concentration: 20700 nM
Beside the measured number, compound 3's estimate is 1.0-fold (0.01 log units) below it, within the range that was stated.
By their numbers in this assay, from the lowest: compound 2; then compound 3; then compound 1.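

Exchanging furan-2-yl for 2-fluorophenyl on a carbon with a double bond to nitrogen gives a 3.8-fold lower number from compound 1 to compound 3 (0.58 log units; beyond the scatter) in this assay. This shows that the hydrogen-bond acceptor counted in furan-2-yl is not required for activity at this position, since the number falls when that acceptor leaves and a six-membered aromatic ring of carbon only enters. Nothing measured here explains why the number falls, so the step remains an observation without a known cause.

The ring and the fluorine enter together, so the compounds shown leave open what a plain phenyl group would give and how much of the step belongs to each. Also open, as far as these compounds go, is how a pyridine ring, or a phenyl ring carrying an amine, would behave at this position.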